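The compounds below may be only part of what the source reports. "The series", "measured", "known", "first", "only" and "open" are said of these compounds alone.

Compound 1, with the structure `Cc1cccc(C(=O)Nc2cc(Cl)ccc2OCC(=O)Nc2ccc(S(N)(=O)=O)cc2C)c1`, and compound 2, with the structure `Cc1cc(S(N)(=O)=O)ccc1NC(=O)COc1ccc(Cl)cc1NC(=O)c1cccc(F)c1`, share one core and differ only in a small group on one aromatic ring. In a functional assay on C8166 cells (Homo sapiens) for cytotoxicity, read by MTT assay (a higher number here means that more compound is tolerated, a lower number that less compound is tolerated), compound 1 gives 52900 nM, while compound 2 gives 243000 nM. Within the data shown here, this is the single measured step, a 4.6-fold higher number from compound 1 to compound 2 (0.66 log units; beyond the scatter), so compound 2 stands as the higher of the two numbers, meaning more of it is tolerated by the cells.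

Compound 3, with the structure `Cc1cc(S(N)(=O)=O)ccc1NC(=O)COc1ccc(Cl)cc1NC(=O)c1cccc(C(F)(F)F)c1`, is the next step from compound 2. Its change is trifluoromethyl in place of fluoro on an aromatic carbon. Among the measured compounds shown here, the only step available for comparison is the one from methyl to fluoro at the same aromatic carbon, which moved the number by a modest but real amount; the new change again swaps a small group at that carbon, but in the other direction of size. Without a closer precedent, a step within the scatter or slightly downward is expected, a 1.6-fold lower number from compound 2 to compound 3 (0.21 log units; within the scatter). Compound 3 is therefore estimated at 150000 nM, with a likely range from 50000 nM to 450000 nM in this assay.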

Compound 3, half-maximal cytotoxic concentration: 124000 nM
Compound 3: middle estimate off by 1.2-fold (0.08 log units), on the high side, and the stated range covers the measured number.
By their numbers in this assay, from the lowest: compound 1; then compounds 3 and 2 (each within the scatter of the next).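

In this assay, putting trifluoromethyl, with 4 heavy atoms, where fluoro, with 1 heavy atom, stood gives a 2.0-fold lower number from compound 2 to compound 3 (0.29 log units; within the scatter), so these two groups cannot be told apart at this aromatic carbon despite the difference in size. Comparing trifluoromethyl with methyl at the same carbon gives a 2.3-fold higher number from compound 1 to compound 3 (0.37 log units; beyond the scatter), a second modest step beyond the scatter that points the same way as a 4.6-fold higher number from compound 1 to compound 2 (0.66 log units; beyond the scatter). Among these three compounds, then, methyl is the group that stands apart, with the lowest number and so the least compound tolerated, while the two fluorine-bearing groups stay within the scatter of each other.

Nothing available here explains why methyl differs from the other two groups. On these data alone, it also remains open whether a chlorine, a methoxy group, an amine or a carboxylic acid at this carbon would group with methyl or with the fluorine-bearing groups, and whether the same separation would appear with these groups elsewhere on this ring.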